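A few compounds are considered here, and "the series" means these few. Any claim that something is new, unique, unknown or untested is made for them only; others in the source may bear on it.

Working notes on the series, read in a toxicity assay on HT-29 cells (Homo sapiens) for cytotoxicity; on this read-out higher numbers stand for lower toxicity in this test and lower numbers for higher toxicity in this test. Compound 1 (`CN1C(=S)[C@@H](NC(=O)c2n[nH]c(Cc3ccccc3)n2)COc2ccccc21`) gives > 50000 nM, which is a limit and not a number. Compound 2 (`CN1C(=S)[C@@H](NC(=O)c2nc(Cc3ccccc3)n(CCCF)n2)COc2ccccc21`) gives > 100000 nM, also a limit, so compound 2 stands without a number. Among the compounds with values here, the only measured step that bears on the next change is a step that the two limits leave unreadable from compound 1 to compound 2, and it offers no size to carry forward. Compound 3 (`CN1C(=S)[C@@H](NC(=O)c2nc(Cc3ccccc3)n(CCCC(F)(F)F)n2)COc2ccccc21`) differs from compound 2 by trifluoromethyl in place of fluoro on a saturated chain carbon, three bonds along the chain from an aromatic nitrogen, with trifluoromethyl in place of fluoro on a saturated chain carbon, three bonds along the chain from an aromatic nitrogen. With no measured size to go on, the limit of compound 2 at > 100000 nM is the sole anchor for the expectation. The expected step is a number no higher from compound 2 to compound 3 (the limit leaves the size open), none beyond the scatter. For compound 3 the estimate is 100000 nM, with an expected range from 50000 nM to 200000 nM, most likely reported again as a limit.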

Compound 3, half-maximal cytotoxic concentration: > 100000 nM
Compound 3: no number, only a limit; the forecaster's own chance of this, stated with the estimate: 85%; the middle value sits exactly at the limit.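

Within the data shown here, compound 3 in this assay gives again a limit and not a number, so no step among compound 1, compound 2 and compound 3 can be read: the limit of > 100000 nM in this assay, at which 2 of the 3 values shown sit. The compounds shown leave open where each true value lies, and whether the 3-fluoropropyl or 4,4,4-trifluorobutyl group changes the read-out at all.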